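Swapping an ester for a chlorophenyl ketone on the shared core

This account rests on a few compounds, and the source may have more. Where it says the series, first, only, none or still open, it means among the compounds named here.

Compound 1, `N#C/C(=C\c1c(-c2ccccc2)[nH]c2ccccc12)C(=O)c1cccs1`: 29000 nM in a functional assay on MCF7 cells (Homo sapiens) for cytotoxicity, read by MTT assay, with a stated time of 96 h; a lower number here means that less compound is needed, a higher number that more compound is needed for the effect
Compound 2, `COCCOC(=O)/C(C#N)=C/c1c(-c2ccccc2)[nH]c2ccccc12`: 12000 nM

Compound 2 gives the lower of the two numbers; the nearest is compound 1, and the step of a 2.4-fold lower number from compound 1 to compound 2 (0.38 log units; beyond the scatter) sets them apart, beyond the scatter. Compound 3, `N#C/C(=C\c1c(-c2ccccc2)[nH]c2ccccc12)C(=O)c1ccc(Cl)cc1`, has not been measured. It differs from compound 2 in one place: 4-chlorophenyl in place of 2-methoxyethoxy on a carbonyl carbon. Within the data shown here, the only measured step that bears on this change is a 2.4-fold lower number from compound 1 to compound 2 (0.38 log units; beyond the scatter), in which an aromatic ring on the carbonyl carbon gave way to the 2-methoxyethoxy chain and the number fell modestly. Compound 3 reverses that kind of change, putting an aromatic ring, though a different one, back on the carbonyl carbon, so a modest rise in the number in this assay is expected, roughly undoing that step. The expected step is a 2.1-fold higher number from compound 2 to compound 3 (0.32 log units; beyond the scatter). For compound 3 the estimate is 25000 nM, with a range from 8000 nM to 70000 nM.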

Compound 3, half-maximal effective concentration: 28000 nM
The estimate for compound 3 lay 1.1-fold (0.05 log units) below the measured number; the measured number falls inside the stated range.
By their numbers in this assay, from the lowest: compound 2; then compounds 3 and 1 (each within the scatter of the next).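

In this assay, exchanging one aromatic ring on the carbonyl carbon for another makes no clear difference: a 1.0-fold lower number from compound 1 to compound 3 (0.02 log units; within the scatter), so 4-chlorophenyl and thiophen-2-yl cannot be told apart here. The 2-methoxyethoxy group stands apart from both rings, with a 2.3-fold higher number from compound 2 to compound 3 (0.37 log units; beyond the scatter), so the earlier difference is now seen with two different rings rather than one. Across these three compounds, the number moves beyond the scatter when a ring and the 2-methoxyethoxy chain are exchanged, but not when one ring replaces the other.

Still open, going by these compounds, is whether the lower number of compound 2 depends on the ester link or on the 2-methoxyethoxy chain, which a methyl ester or a morpholine amide at this carbonyl carbon could help to separate. No measurement shown explains the difference between the chain and the rings.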